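Glycinamide benzophenone series: rotarod dose notes

This account rests on a few compounds, and the source may have more. Where it says the series, first, only, none or still open, it means among the compounds named here.

Measured so far in a functional assay on the whole organism with Mus musculus as the target, in the rotarod test; a higher number here means that more compound is needed for the effect, a lower number that less compound is needed:
Compound 1 `CC(NC(=O)CN)C(=O)N(C)c1ccc(Cl)cc1C(=O)c1ccccc1Cl` gives 8.5 mg/kg.
Compound 2 `CCCCCC(=O)NCC(=O)N(C)c1ccc(Cl)cc1C(=O)c1ccccc1Cl` gives 90 mg/kg.
Compound 3 `CN1CCN(CC(=O)NCC(=O)N(C)c2ccc(Cl)cc2C(=O)c2ccccc2Cl)CC1` gives only a limit of the assay, > 100 mg/kg.

Compound 3 thus stands at the limit, the weakest datum on the numbers shown, and its exact place is unknown (the limit of > 100 mg/kg in this assay, at which 1 of the 3 values shown sits). Compound 4 `CCCCC(=O)NCC(=O)N(C)c1ccc(Cl)cc1C(=O)c1ccccc1Cl` is the next candidate; the change from compound 3 is propyl in place of 4-methylpiperazin-1-yl on a saturated chain carbon bound to a carbonyl carbon. The step of an at least 1.1-fold higher number from compound 2 to compound 3 (0.04 log units; that floor lies within the scatter) is the one that bears on it, as it put the 4-methylpiperazin-1-yl group in, and that step stayed within the scatter at its floor; the earlier step of an 11-fold higher number from compound 1 to compound 2 (1.02 log units; beyond the scatter) is larger but concerns a different part of the chain. Replacing the 4-methylpiperazin-1-yl group by propyl is therefore expected to give for compound 4 a step of about an at least 1.2-fold lower number from compound 3 to compound 4 (0.09 log units; that floor lies within the scatter), that is, a number close to or somewhat below the limit. The estimate for compound 4 in this assay is 80 mg/kg, within 30 mg/kg to 200 mg/kg.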

Compound 4, dose for half-maximal effect: 90 mg/kg
Compound 4: middle estimate off by 1.1-fold (0.05 log units), on the low side; the measured number falls inside the stated range.
By their numbers in this assay, from the lowest: compound 1; then compounds 2 and 4 (each within the scatter of the next). At a limit, above all of these: compound 3.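

In this assay, hydrogen in place of methyl on a saturated chain carbon, four bonds along the chain from a carbonyl carbon, gives this step: no change at the digits printed from compound 2 to compound 4 (within the scatter). This chain length therefore does not separate the two amides. The butylcarbonyl compound keeps the gap to the amine-bearing compound: an 11-fold higher number from compound 1 to compound 4 (1.02 log units; beyond the scatter). Compound 3 stands at a limit of the assay: the limit of > 100 mg/kg in this assay, at which 1 of the 4 values shown sits. The step away from that limit can be given only as a floor: an at least 1.1-fold lower number from compound 3 to compound 4 (0.04 log units; that floor lies within the scatter).

Open, on these data alone, is which part of the 1-(((aminomethyl)carbonyl)amino)ethyl group carries that gap; the same amine without the methyl on the ethyl carbon would separate them. An acetyl group would test a much shorter chain.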